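The compounds below may be only part of what the source reports. "The series", "measured", "known", "first", "only" and "open" are said of these compounds alone.

Measured so far:
- compound 1, `O=C(Cn1cc(-c2ccc(F)cc2)nn1)Nc1nccs1`: in a functional assay on BMDM cells (Mus musculus, strain C57BL/6) for inhibition, with a stated time of 2 days (on this read-out lower numbers stand for stronger inhibition and higher numbers for weaker inhibition), compound 1 gives 190 nM.
- compound 2, `Cc1cc(NC(=O)Cn2cc(-c3ccc(F)cc3)nn2)no1`: in this assay compound 2 reaches only a limit, > 30000 nM.
- compound 3, `COC(=O)c1ccc(-c2cn(CC(=O)Nc3nc(C)cs3)nn2)cc1`: in this assay compound 3 likewise reaches only a limit, > 30000 nM.

Compound 3 thus stands at the limit of > 30000 nM in this assay, at which 2 of the 3 values shown sit, with no number of its own. The step to compound 4, `Cc1csc(NC(=O)Cn2cc(-c3ccc(F)cc3)nn2)n1`, is fluoro in place of methoxycarbonyl on an aromatic carbon. Among the measured compounds shown here, the only measured step, an at least 150-fold higher number from compound 1 to compound 2 (2.19 log units; beyond the scatter), concerns the group on the amide-type nitrogen and not the aromatic carbon changed here, so it does not bear directly on the present step. What does bear on it is that compound 1, which carries the same fluoro group on the same six-membered aromatic ring, gives 190 nM in this assay. For the measured compounds named here, compound 3, the only compound bearing methoxycarbonyl, sits at the limit. A large downward step, an at least 30-fold lower number from compound 3 to compound 4 (1.47 log units; beyond the scatter), is therefore expected. Compound 4 is estimated at 1000 nM, within 250 nM to 8000 nM.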

Compound 4, half-maximal inhibitory concentration: 250 nM
For compound 4 the middle estimate is 4.0-fold (0.60 log units) above the measured one; measured number inside the range.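

In this assay, fluoro in place of methoxycarbonyl on an aromatic carbon, para to a large group, gives an at least 120-fold lower number from compound 3 to compound 4 (2.07 log units; beyond the scatter), so this position alone decides between a measurable value and the limit seen for compound 3: the limit of > 30000 nM in this assay, at which 2 of the 4 values shown sit. The methyl on the thiazole does not account for that limit, as methyl in place of hydrogen gives only a 1.3-fold higher number from compound 1 to compound 4 (0.12 log units; within the scatter). With a methyl on both groups, 4-methyl-1,3-thiazol-2-yl in place of 5-methyl-1,2-oxazol-3-yl on the amide-type nitrogen gives an at least 120-fold lower number from compound 2 to compound 4 (2.07 log units; beyond the scatter), which ties the earlier drop to the ring there.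

The compounds shown hold only fluoro and methoxycarbonyl at this position, so a chloro group, an amine or a carboxylic acid there remains open. Going by these compounds, the true size of the step also stays open, as compound 3 has only a limit.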